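A few compounds are considered here, and "the series" means these few. Any claim that something is new, unique, unknown or untested is made for them only; others in the source may bear on it.

Compound 1 `CC(=O)Cn1nnnc1Cc1ccc(-c2ccccc2)cc1` and compound 2 `CC(=O)Cn1nnc(Cc2ccc(-c3ccccc3)cc2)n1` share one core and were both tested in an assay on isolated protein (COS cells) for inhibition of diacylglycerol lipase-alpha (Homo sapiens); on this read-out higher numbers stand for weaker inhibition and lower numbers for stronger inhibition. For compound 1 the result is a limit of the assay, > 10000 nM, and not a number. For compound 2 the result is likewise a limit, > 10000 nM. Among the measured compounds shown here, compound 2 therefore stands at the limit of > 10000 nM in this assay, at which 2 of the 2 values shown sit, so no measured step can be set against it. Compound 3 `CC(C)Cn1nnc(Cc2ccc(-c3ccccc3)cc2)n1` differs from compound 2 by isopropyl in place of acetyl on a saturated chain carbon bound to an aromatic nitrogen. With nothing but a limit to start from, the step from compound 2 to compound 3 is expected to stay within the scatter, a step that the limit leaves unreadable from compound 2 to compound 3. Compound 3 is therefore estimated at 12000 nM, between 4000 nM and 40000 nM.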

Compound 3, half-maximal inhibitory concentration: > 10000 nM
Compound 3: no number, only a limit; the forecaster's own chance of this, stated with the estimate: 75%; the middle value lies beyond the limit too.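

Compound 2 and compound 3 both end at a limit of the assay, so no step can be read between them: the limit of > 10000 nM in this assay, at which 3 of the 3 values shown sit.

The compounds shown leave open whether isopropyl in place of acetyl changes inhibition at all.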